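The source may hold more compounds than are shown below. What is called first, only, known or untested is meant among the compounds shown, and "the series" means these compounds.

Measured so far in an assay on HEK293 cells for agonist activity at Toll-like receptor 8 (Homo sapiens), read by spectrophotometry; a lower number here means that less compound is needed, a higher number that more compound is needed for the effect:
- compound 1 `C#Cc1c(C)nc(N)nc1NCCCC` gives 4900 nM
- compound 2 `CCCCNc1nc(N)nc(C)c1CCCCO` gives 1310 nM
- compound 3 `CCCCCc1c(C)nc(N)nc1NCCCC` gives 1220 nM

Compound 2 stands second highest of the three numbers, within the scatter of compound 3 and well apart from compound 1, which showed a 3.7-fold lower number from compound 1 to compound 2 (0.57 log units; beyond the scatter). Compound 4 `CCCCNc1nc(N)nc(C)c1CCCC` differs from compound 2 by hydrogen in place of hydroxy on a saturated chain carbon, four bonds along the chain from an aromatic carbon. The measured step that bears on this is the one where methyl replaced hydroxy at the same place on the chain: a 1.1-fold lower number from compound 2 to compound 3 (0.03 log units; within the scatter). Taking the hydroxy away altogether is expected to behave much the same, so for compound 4 the expected step is a 1.0-fold lower number from compound 2 to compound 4 (0.02 log units; within the scatter), nothing beyond the scatter. Compound 4 is therefore estimated at 1250 nM, with a range from 600 nM to 2600 nM.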

Compound 4, half-maximal effective concentration: 780 nM
Compound 4: the middle estimate sits 1.6-fold (0.20 log units) above what was measured, within the range that was stated.
By their numbers in this assay, from the lowest: compounds 4, 3 and 2 (each within the scatter of the next); then compound 1.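

In this assay the end of this chain seems to matter little: hydroxy, methyl and hydrogen there cannot be told apart, with a 1.7-fold lower number from compound 2 to compound 4 (0.23 log units; within the scatter) and a 1.6-fold lower number from compound 3 to compound 4 (0.19 log units; within the scatter) both printed as within the scatter. Ethynyl on the aromatic carbon stands apart, and a 6.3-fold lower number from compound 1 to compound 4 (0.80 log units; beyond the scatter) is the widest step among these compounds. Nothing measured here gives a reason for either finding. As far as these compounds go, whether an amine or a carboxylic acid at the chain end would fit the same picture stays open, as does a longer chain.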